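A few compounds are considered here, and "the series" means these few. Any claim that something is new, unique, unknown or untested is made for them only; others in the source may bear on it.

Compound 1, whose structure is `Cc1cc(-n2cc(C(=O)Nc3cc(F)cc(F)c3)c(=O)c3ccc(N(C)C)nc32)ccc1OCCCCCCC[N+]12CCN(CC1)CC2`, is measured in an assay on LX2 cells for inhibition of COL1A1 promoter (Homo sapiens), read by a luciferase reporter, with a stated time of 24 h, tested at 50 uM (a higher number here means a stronger effect of the compound at the concentration tested, a lower number a weaker effect), and in that assay compound 1 gives 20.8%. Compound 2, `CN(C)c1ccc2c(=O)c(C(=O)Nc3cc(F)cc(F)c3)cn(-c3ccc(OCCCCCCC[N+]45CCN(CC4)CC5)c(Cl)c3)c2n1`, differs from it by one change, (chloro in place of methyl on an aromatic carbon), and in this assay compound 2 gives 20.5%, so that the step is a number 0.3 percentage points lower from compound 1 to compound 2 (within the scatter).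

Compound 3, `Cc1cc(OCCCCCCC[N+]2(C)CCCC2)ccc1-n1cc(C(=O)Nc2cc(F)cc(F)c2)c(=O)c2ccc(N(C)C)nc21`, shares the same arrangement at the aromatic ring but carries a different end on its chain; how its core differs from that of compound 1 is not broken down here. In this assay compound 3 is reported as "not active" (no number reported). Compound 4, `CN(C)c1ccc2c(=O)c(C(=O)Nc3cc(F)cc(F)c3)cn(-c3ccc(OCCCCCCC[N+]4(C)CCCC4)cc3Cl)c2n1`, is not yet measured; it differs from compound 3 by chloro in place of methyl on an aromatic carbon, the same change, at the same described place, that was made from compound 1 to compound 2.

Since that earlier step, a number 0.3 percentage points lower from compound 1 to compound 2 (within the scatter), lay within the scatter, the same change is expected to move little here as well, and as compound 3 is reported not active, compound 4 is expected to give 8%, within a range of 0% to 22%.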

Compound 4, a percentage reported as inhibition, at one concentration (the size of the read-out at that concentration, not a potency): "not active" (no number reported)
For compound 4 the study gives words and no number, and the estimate cannot be compared.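

Within the data shown here, compound 3 and compound 4 are both reported in words only, without a number, so no step between them can be read in this assay. Nothing shown offers an explanation for this result. The compounds shown leave open whether chloro in place of methyl has any measurable effect when the chain carries the end found in compound 3.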